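A few compounds are considered here, and "the series" means these few. Any claim that something is new, unique, unknown or untested is made for them only; others in the source may bear on it.

Of the compounds shown here, three from this series have been tested in a functional assay on LNCaP C4-2 cells (Homo sapiens) for cytotoxicity, read by MTT assay, with a stated time of 48 h, in the absence of a further agent (on this read-out higher numbers stand for weaker inhibition and lower numbers for stronger inhibition), and none of them has produced a number. Compound 1 `O=C(NCc1ccccc1)c1csc(-c2c[nH]c3ccccc23)n1` is the simplest of the three. In this assay compound 1 gives > 100000 nM, which is a limit of the assay rather than a measured value. Compound 2 `COc1ccc(NC(=O)c2csc(-c3cn(Cc4ccc(Cl)cc4)c4ccccc34)n2)cc1` is a second variation on the shared core. In this assay compound 2 gives > 100000 nM, again only a limit. Compound 3 `COc1ccc2[nH]cc(-c3nc(C(=O)Nc4cc(OC)c(OC)c(OC)c4)cs3)c2c1` stands in the same place: in this assay compound 3 gives > 100000 nM, also a limit. Among the measured compounds shown here, every result so far is therefore (the limit of > 100000 nM in this assay, at which 3 of the 3 values shown sit), so compound 3 cannot be ranked against the other two, and no pair of compounds that differ in just one place has been measured, so no step size is known.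

Compound 4 `COc1cc(NC(=O)c2csc(-c3c[nH]c4ccc(Br)cc34)n2)cc(OC)c1OC` has not been tested. It differs from compound 3 by bromo in place of methoxy on an aromatic carbon. With nothing but limits to build on, the step from compound 3 to compound 4, a number no higher from compound 3 to compound 4 (the limit leaves the size open), is expected to be none beyond the scatter. Compound 4 is therefore estimated at 100000 nM, in a range from 20000 nM to 300000 nM.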

Compound 4, half-maximal inhibitory concentration: > 100000 nM
Compound 4 gave a limit, no number (the forecaster's own chance of this, stated with the estimate: 70%); the middle value sits exactly at the limit.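

Compound 3 and compound 4 both give only a limit in this assay, so the step from methoxy to bromo on an aromatic carbon cannot be read. The compounds shown leave open whether any change to the shared core gives a measured number, and how large any step would be, with every result resting on one limit: the limit of > 100000 nM in this assay, at which 4 of the 4 values shown sit.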